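The source may hold more compounds than are shown below. What is called first, only, known or untested is meant among the compounds shown, and "the series" means these compounds.

Compound 1 `CCCCCCCCc1cn([C@@H]2O[C@H](CO)[C@@H](O)[C@H]2O)nn1` carries a heptyl on the saturated chain carbon bound to an aromatic carbon of the shared core; in a functional assay on CCRF-CEM cells (Homo sapiens) (on this read-out lower numbers stand for stronger inhibition and higher numbers for weaker inhibition), compound 1 gives 44000 nM. Compound 2 `OCc1cn([C@@H]2O[C@H](CO)[C@@H](O)[C@H]2O)nn1` carries a hydroxy in that place. For compound 2 this assay reports only a limit, > 200000 nM. This is the limit of > 200000 nM in this assay, at which 1 of the 2 values shown sits. The one measured step, an at least 4.5-fold higher number from compound 1 to compound 2 (0.65 log units; beyond the scatter), therefore places compound 2 at the weak end of the two results shown, without an exact number. Compound 3 `OC[C@H]1O[C@@H](n2cc(-c3ccsc3)nn2)[C@H](O)[C@@H]1O` differs from compound 2 by thiophen-3-yl in place of hydroxymethyl on an aromatic carbon. Going by the values given here, no measured pair shows this exact change; the only step that bears on it is an at least 4.5-fold higher number from compound 1 to compound 2 (0.65 log units; beyond the scatter), where loss of the heptyl weakened inhibition, and compound 3 likewise removes the hydroxy-bearing group, here for a ring rather than a chain. A step toward stronger inhibition is therefore expected, of size an at least 2.2-fold lower number from compound 2 to compound 3 (0.34 log units; beyond the scatter), although the starting point is uncertain since compound 2 is known only as a limit. Compound 3 is estimated at 90000 nM in this assay, with a range from 30000 nM to 250000 nM.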

Compound 3, half-maximal inhibitory concentration: 139000 nM
Estimate against measurement, compound 3: 1.5-fold (0.19 log units) below, and the stated range covers the measured number.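

On the aromatic carbon next to the ring nitrogen, thiophen-3-yl gives compound 3 an exact number in this assay, whereas hydroxymethyl left compound 2 without one. The change reads as an at least 1.4-fold lower number from compound 2 to compound 3 (0.15 log units; that floor lies within the scatter), so these data do not establish that the thiophen-3-yl ring gives stronger inhibition than hydroxymethyl at this position, although a larger gain is not excluded. The true size of the step cannot be fixed because compound 2 is known only as a limit: the limit of > 200000 nM in this assay, at which 1 of the 3 values shown sits.

At this position the series offers only a chain-bearing comparison from the printed values, with compound 1 at 44000 nM and compound 3 at 139000 nM, so one aromatic ring and one long alkyl chain are all that can be set side by side. As far as these compounds go, whether a phenyl ring, thiophen-2-yl, an amine or a longer chain on this carbon would change the number remains open, as does whether the thiophen-3-yl result reflects aromatic rings in general or this ring alone.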